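The compounds below may be only part of what the source reports. "The series", "measured", "known", "first", "only" and "open" are said of these compounds alone.

Of the compounds shown here, three sharing one core have been measured in an assay on isolated protein for binding affinity to 5-hydroxytryptamine receptor 6 (Homo sapiens); a higher number here means a weaker inhibitor, a lower number a stronger inhibitor. Compound 1 `c1ccc(-c2n[nH]cc2N2CCNCC2)cc1` gives 185 nM. Compound 2 `Clc1cccc(-c2n[nH]cc2N2CCNCC2)c1` gives 109 nM, and compound 3 `Clc1ccc(-c2n[nH]cc2N2CCNCC2)cc1` gives 75 nM. Compound 3 thus holds the lowest of the three numbers; its gap to compound 2 is within the scatter, while a 2.5-fold lower number from compound 1 to compound 3 (0.39 log units; beyond the scatter) lies beyond it, a modest step. Compound 4 `Cc1ccc(-c2n[nH]cc2N2CCNCC2)cc1` differs from compound 3 by methyl in place of chloro on an aromatic carbon, the incoming group sitting on an aromatic carbon of a six-membered aromatic ring of carbon only, para to a large group. Among the measured compounds shown here, the measured steps that bear on this are the chloro-for-hydrogen steps, of which a 1.7-fold lower number from compound 1 to compound 2 (0.23 log units; within the scatter) is the other; no measured pair sets methyl against chloro directly. Both known steps were small. The swap is therefore expected to move this assay little, probably not beyond the scatter, with a slight lean toward a higher number, giving an expected step of a 1.5-fold higher number from compound 3 to compound 4 (0.17 log units; within the scatter). Compound 4 is estimated at 110 nM, with a range from 55 nM to 220 nM.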

Compound 4, inhibition constant: 653 nM
Estimate against measurement, compound 4: 5.9-fold (0.77 log units) below; the whole stated range lies below it.
By their numbers in this assay, from the lowest: compounds 3, 2 and 1 (each within the scatter of the next, the first and the last beyond it); then compound 4.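

At this position, on an aromatic carbon para to a large group, chloro and methyl are far from interchangeable in this assay: the swap gives an 8.7-fold higher number from compound 3 to compound 4 (0.94 log units; beyond the scatter), even though each group counts just one heavy atom. Methyl also gives a weaker inhibitor than hydrogen, with a 3.5-fold higher number from compound 1 to compound 4 (0.55 log units; beyond the scatter), while chloro at the same place gave a 2.5-fold lower number from compound 1 to compound 3 (0.39 log units; beyond the scatter), so a single-atom change here can move the number in either direction. No measurement available here explains the difference between the two groups.

From the compounds shown here alone, it remains open whether other groups at this place, such as fluoro, bromo, methoxy or trifluoromethyl, would track with chloro or with methyl. Going by these compounds, it is also open whether methyl would carry a similar penalty in place of the chloro of compound 2.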